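The source may hold more compounds than are shown below. What is called first, only, known or untested is meant among the compounds shown, and "the series" means these compounds.

Series, measured for antiproliferative activity in a functional assay on B16-F10 cells (Mus musculus) for antiproliferative activity, read by MTT assay, with a stated time of 48 h; a higher number here means a weaker inhibitor, a lower number a stronger inhibitor:

compound 1 `CCCCOc1ccc(C(=O)/C=C/c2c(/C=C/c3ccc(OC)cc3)cc(OC)cc2OC)cc1`: 5.3 ug/mL
compound 2 `COc1ccc(/C=C/c2cc(OC)cc(OC)c2/C=C/C(=O)c2ccc(N)cc2)cc1`: 2.8 ug/mL
compound 3 `COc1ccc(/C=C/c2cc(OC)cc(OC)c2/C=C/C(=O)c2ccc(C(F)(F)F)cc2)cc1`: 4.3 ug/mL

Compound 3 holds the second highest of the three numbers in this assay; its nearest neighbour is compound 1 and its furthest is compound 2, and both gaps lie within the scatter. The three measured compounds differ from one another only at a single aromatic carbon of the shared core. The steps of a 1.2-fold lower number from compound 1 to compound 3 (0.09 log units; within the scatter) and a 1.5-fold higher number from compound 2 to compound 3 (0.19 log units; within the scatter) are both small, as is a 1.9-fold lower number from compound 1 to compound 2 (0.28 log units; within the scatter); none of the three exchanges made at that carbon has moved the number beyond the scatter.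

Compound 4 `COc1ccc(/C=C/c2cc(OC)cc(OC)c2/C=C/C(=O)c2ccc(C)c(C)c2)cc1` changes the same region: 3,4-dimethylphenyl in place of 4-(trifluoromethyl)phenyl on a carbonyl carbon. Going by the values given here, the steps that bear on this are those already given, from compound 1 and from compound 2 to compound 3, which exchanged groups on that aromatic carbon and stayed within the scatter. Among the compounds with values here, a dimethylphenyl has no direct precedent here, so nothing in the data points to a step beyond the scatter in either direction. Compound 4 is therefore expected to give about 4.3 ug/mL in this assay, estimated to fall between 2.3 ug/mL and 8 ug/mL. For compound 4 the expected step is no change at the digits printed from compound 3 to compound 4 (within the scatter), within the usual scatter.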

Compound 4, half-maximal inhibitory concentration: 1.4 ug/mL
Estimate against measurement, compound 4: 3.1-fold (0.49 log units) above, outside the stated range (below it).
By their numbers in this assay, from the lowest: compounds 4, 2, 3 and 1 (each within the scatter of the next, the first and the last beyond it).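

In this assay, going by these compounds alone, the aryl group on the carbonyl carbon now shows that an exchange at this place can move the number beyond the scatter, which no step among the earlier compounds did: 3,4-dimethylphenyl in place of 4-(trifluoromethyl)phenyl gives a 3.1-fold lower number from compound 3 to compound 4 (0.49 log units; beyond the scatter), and 3,4-dimethylphenyl in place of 4-butoxyphenyl gives a 3.8-fold lower number from compound 1 to compound 4 (0.58 log units; beyond the scatter). Compound 2 goes against any general gain for this group, since 3,4-dimethylphenyl in place of 4-aminophenyl gives only a 2.0-fold lower number from compound 2 to compound 4 (0.30 log units; within the scatter), so the place is sensitive to the change against two of the three earlier groups but not against the third. Nothing available explains why the dimethylphenyl separates from the trifluoromethyl and butoxy compounds and not from the amino compound.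

From the compounds shown here alone, whether a single methyl on the ring would do the same as the two methyls of 3,4-dimethylphenyl stays open, as does the outcome with a chlorine or a carboxylic acid on that ring. Every compound shown varies only this aryl group, so how the rest of the shared core contributes also remains open.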